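The source may report more compounds than this note shows. Statements on the series, on what has been measured and on what is new or still open speak of the compounds shown alone.

Of the compounds shown here, three built on one shared core have been tested in a functional assay on A549 cells (Homo sapiens) for antiproliferative activity, read by MTT assay, with a stated time of 72 h; on this read-out higher numbers stand for weaker inhibition and lower numbers for stronger inhibition. Compound 1 `O=C(N/N=C/c1ccccc1)Nc1ccc(Oc2ccnc3[nH]ccc23)c(F)c1` gives 2500 nM in this assay. Compound 2 `O=C(N/N=C/c1ccc(Br)cc1)Nc1ccc(Oc2ccnc3[nH]ccc23)c(F)c1` gives 820 nM, and compound 3 `N#Cc1ccc(/C=N/NC(=O)Nc2ccc(Oc3ccnc4[nH]ccc34)c(F)c2)cc1` gives 1360 nM. The number for compound 3 lies between the other two, and both of its measured steps, a 1.7-fold higher number from compound 2 to compound 3 (0.22 log units; within the scatter) and a 1.8-fold lower number from compound 1 to compound 3 (0.26 log units; within the scatter), fall within the usual scatter, so the three cannot be ranked with confidence. Compound 4 `O=C(N/N=C/c1cccc(Cl)c1Cl)Nc1ccc(Oc2ccnc3[nH]ccc23)c(F)c1` differs from compound 3 in one place: 2,3-dichlorophenyl in place of 4-cyanophenyl on a carbon with a double bond to nitrogen. The step that bears most on this change is a 3.0-fold lower number from compound 1 to compound 2 (0.48 log units; beyond the scatter), where bromo took the place of hydrogen on an aromatic carbon and gave a modest improvement; the cyano change stayed within the scatter. Among the measured compounds shown here, a 2,3-dichlorophenyl group has no direct precedent among the measured compounds, so the expectation rests on the bromo step alone. Compound 4 is expected to show a 1.5-fold lower number from compound 3 to compound 4 (0.18 log units; within the scatter), a modest lowering with a wide range. Compound 4 is therefore estimated at 900 nM in this assay, between 350 nM and 2300 nM.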

Compound 4, half-maximal inhibitory concentration: "not active" (no number reported)
No number was reported for compound 4; no gap can be computed for the estimate.
By their numbers in this assay, from the lowest: compounds 2, 3 and 1 (each within the scatter of the next, the first and the last beyond it).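

In this assay, among the compounds shown here, compound 4 is reported only as "not active", with no number, so no step from compound 3 to compound 4 can be read. No measurement shown here offers an explanation for this result. On these data alone, how far compound 4 lies from compound 3, and what the 2,3-dichlorophenyl group contributes, stay open.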